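The compounds below may be only part of what the source reports. "The series", "measured", "known", "first", "only" and "open" are said of these compounds alone.

Series notes, measured in a functional assay on HeLa cells (Homo sapiens) for antiproliferative activity, read by CCK-8 assay, with a stated time of 72 h; a lower number here means a stronger inhibitor of growth, a higher number a weaker inhibitor of growth:
- compound 1 `CCC1C(=O)N(C)c2cnc(-n3ccc4cc(C(=O)NC(C)C)ccc43)nc2N1c1ccn(C)n1` gives 4350 nM
- compound 2 `CCC1C(=O)N(C)c2cnc(Nc3ccc(S(=O)(=O)NCCO)cc3)nc2N1c1ccn(C)n1` gives "not active" (no number reported)
- compound 3 `CC[C@@H]1C(=O)N(C)c2cnc(-n3ccc4cc(F)ccc43)nc2N1C1CCCC1` gives "not active" (no number reported)

For the measured compounds named here, compound 1 holds the only number, since compound 2 and compound 3 give no number. Compound 4 `CCNC(=O)c1ccc2c(ccn2-c2ncc3c(n2)N(c2ccn(C)n2)C(CC)C(=O)N3C)c1` is still unmeasured. It departs from compound 1 by one small change, isopropylcarbamoyl to ethylcarbamoyl: hydrogen in place of methyl on a saturated chain carbon bound to an amide-type nitrogen and a saturated chain carbon. Going by the values given here, no measured pair offers a step to guide this change, so no direction is favoured and no shift beyond the scatter is expected in this assay. The expected change is a 1.1-fold higher number from compound 1 to compound 4 (0.04 log units; within the scatter). The estimate for compound 4 is 4800 nM, with an expected range of 2000 nM to 12000 nM.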

Compound 4, concentration for 50% growth inhibition: 11100 nM
The estimate for compound 4 lay 2.3-fold (0.36 log units) below the measured number; the measured number falls inside the stated range.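

In this assay, for the compounds shown here, the change from isopropylcarbamoyl to ethylcarbamoyl gives a 2.6-fold higher number from compound 1 to compound 4 (0.41 log units; beyond the scatter) and is the only readable step. Losing this one methyl from the saturated chain therefore weakens growth inhibition modestly, a finding that rests on this single pair. No measurement shown accounts for the shift. A single step gives no trend along the chain. On these data alone, how a tert-butyl group, a cyclopropyl group or a longer chain such as n-butyl on the amide nitrogen would read remains open.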